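This account rests on a few compounds, and the source may have more. Where it says the series, first, only, none or still open, it means among the compounds named here.

Compound 2 `CC(C(=O)NCc1ccc(C(F)(F)F)nc1N(Cc1ccc(Cl)cc1)S(=O)(=O)c1ccc(F)cc1)c1ccc(NS(C)(=O)=O)c(F)c1` gives the lowest number of the two measured here in an assay on CHO cells for displacement of a labelled ligand from transient receptor potential cation channel subfamily V member 1 (Homo sapiens), read by scintillation counting, with a stated time of 60 min (a higher number here means a weaker inhibitor, a lower number a stronger inhibitor), at 0.9 nM, while compound 1 `CC(C(=O)NCc1ccc(C(F)(F)F)nc1N(Cc1ccccc1)S(=O)(=O)c1ccc(F)cc1)c1ccc(NS(C)(=O)=O)c(F)c1` gives 1.56 nM; the step of a 1.7-fold lower number from compound 1 to compound 2 (0.24 log units; within the scatter) is within the scatter. Compound 3 `Cc1ccc(CN(c2nc(C(F)(F)F)ccc2CNC(=O)C(C)c2ccc(NS(C)(=O)=O)c(F)c2)S(=O)(=O)c2ccc(F)cc2)cc1` carries methyl in place of chloro on an aromatic carbon. Going by the values given here, the only step that bears on this position is the one from hydrogen to chloro, and it stayed within the scatter, so no step beyond the scatter is expected in this assay. The expected step is a 1.3-fold higher number from compound 2 to compound 3 (0.12 log units; within the scatter). Compound 3 is therefore estimated at 1.2 nM, with a range from 0.5 nM to 3 nM.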

Compound 3, inhibition constant: 3.28 nM
Estimate against measurement, compound 3: 2.7-fold (0.44 log units) below; measured number above the stated range.
By their numbers in this assay, from the lowest: compounds 2 and 1 (each within the scatter of the next); then compound 3.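

In this assay the position turns out to be sensitive to what it carries: methyl gives a 3.6-fold higher number from compound 2 to compound 3 (0.56 log units; beyond the scatter) and also a 2.1-fold higher number from compound 1 to compound 3 (0.32 log units; beyond the scatter), both beyond the scatter, whereas the earlier step from hydrogen to chloro stayed within it. Chloro and methyl, each a single heavy atom with no hydrogen-bond donors or acceptors, are therefore not interchangeable here. No measurement at hand accounts for this difference.

On these data alone, whether a methoxy group, an amine or a carboxylic acid at this position would sit with chloro or with methyl stays open. So does whether a longer chain such as ethyl would carry the methyl step further.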